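Sulfone to Sulfonamide: What Compound 4 Might Show

This account rests on a few compounds, and the source may have more. Where it says the series, first, only, none or still open, it means among the compounds named here.

Three compounds built on the core of compound 1 `CC(O)(C(=O)Nc1ccc(S(=O)(=O)c2ccc(F)cc2)cc1)C(F)(F)F` have been measured in a functional assay (Cavia porcellus) with sulfonylurea receptors; K-ATP channels (Homo sapiens) as the target; on this read-out higher numbers stand for weaker inhibition and lower numbers for stronger inhibition. Compound 1 gives 8600 nM, the highest of the three numbers. Compound 2 `CC(O)(C(=O)Nc1ccc(S(=O)(=O)c2ccccc2)c(C#N)c1)C(F)(F)F` gives 3800 nM, and compound 3 `COc1cc(NC(=O)C(C)(O)C(F)(F)F)ccc1S(=O)(=O)c1ccccc1` gives 5900 nM. The gap between compound 1 and compound 3 lies within the scatter, whereas the gap between compound 1 and compound 2 lies beyond it. Among the measured compounds shown here, the only step between two compounds differing in one place is a 1.6-fold higher number from compound 2 to compound 3 (0.19 log units; within the scatter), which concerns a substituent on the aromatic ring bearing the amide and does not rise above the scatter.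

Compound 4 `CN(c1ccccc1)S(=O)(=O)c1ccc(NC(=O)C(C)(O)C(F)(F)F)cc1` differs from compound 1 at the sulfonyl sulfur: methyl(phenyl)amino in place of 4-fluorophenyl on a sulfonyl sulfur. For the measured compounds named here, no measured step touches this position; the step from compound 2 to compound 3 lies on the other ring and gives no direct guidance. The three measured values all sit within a narrow band, and nothing in them points to a change in either direction. For compound 4 the expected value in this assay is therefore 10000 nM, with a range from 4000 nM to 25000 nM. The expected step, a 1.2-fold higher number from compound 1 to compound 4 (0.07 log units; within the scatter), is not anticipated to exceed the scatter.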

Compound 4, half-maximal inhibitory concentration: 2000 nM
Beside the measured number, compound 4's estimate is 5.0-fold (0.70 log units) above it; measured number below the stated range.
By their numbers in this assay, from the lowest: compounds 4, 2, 3 and 1 (each within the scatter of the next, the first and the last beyond it).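

Within this assay, the change of 4-fluorophenyl to methyl(phenyl)amino on a sulfonyl sulfur gives a 4.3-fold lower number from compound 1 to compound 4 (0.63 log units; beyond the scatter) and so marks this position as one where the number can move beyond the scatter, which the only earlier one-place step, a 1.6-fold higher number from compound 2 to compound 3 (0.19 log units; within the scatter), did not show for its own position. The change keeps one six-membered aromatic ring of carbon only and the same counts of hydrogen-bond donors and acceptors, yet it swaps several things in a single step: a nitrogen and a methyl enter while the fluorine leaves, and this one pair cannot separate their shares in the lower number. Nothing in the data shown accounts for the step. The compounds shown leave open whether the methyl matters, as phenylamino with a hydrogen in its place would test, and whether the aromatic ring matters, as a saturated amine such as piperidine on the sulfonyl sulfur would test. They also leave open whether the step holds when the nitrile of compound 2 is present on the shared core.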